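A few compounds are considered here, and "the series" means these few. Any claim that something is new, unique, unknown or untested is made for them only; others in the source may bear on it.

Measured so far in a functional assay on A549 cells (Homo sapiens) for cytotoxicity, read by MTT assay, with a stated time of 72 h; a lower number here means a stronger inhibitor, a higher number a weaker inhibitor:
compound 1 `CNC(=O)c1cc(Oc2ccc(C3=NNC(c4cccc(Br)c4)C3)cc2)ccn1`: 2840 nM
compound 2 `CNC(=O)c1cc(Oc2ccc(C3=NNC(c4ccc([N+](=O)[O-])cc4)C3)cc2)ccn1`: 19500 nM
compound 3 `CNC(=O)c1cc(Oc2ccc(C3=NNC(c4cccc([N+](=O)[O-])c4)C3)cc2)ccn1`: "not determined" (no result reported)

Compound 3 has no single number in this assay and so cannot be placed relative to compound 1 or compound 2. Compound 4 `CNC(=O)c1cc(Oc2ccc(C3=NNC(c4cccc(Cl)c4Cl)C3)cc2)ccn1` has not yet been measured. The change from compound 3 is 2,3-dichlorophenyl in place of 3-nitrophenyl on a saturated ring carbon.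

Going by the values given here, with no number for compound 3, the only guide is the one measured step, a 6.9-fold higher number from compound 1 to compound 2 (0.84 log units; beyond the scatter), where 4-nitrophenyl replaces 3-bromophenyl on the same saturated ring carbon. That step is modest but beyond the scatter. A single step sets no trend, but it does show that the aryl group at this carbon can move the number. Going from a nitrophenyl to a halogen-bearing phenyl runs opposite to that step, so a modest step toward a lower number is expected, of similar size or smaller. The closest reference is compound 1 at 2840 nM, and a value in that region is expected, with the uncertainty kept wide. For compound 4 the estimated value is 4000 nM with an expected range of 1300 nM to 13000 nM for now.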

Compound 4, half-maximal inhibitory concentration: 12100 nM
Compound 4: middle estimate off by 3.0-fold (0.48 log units), on the low side, within the range that was stated.
By their numbers in this assay, from the lowest: compound 1; then compounds 4 and 2 (each within the scatter of the next).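

In this assay, a nitrophenyl and a halogen-bearing phenyl at this saturated ring carbon are not separated by the pair showing a 1.6-fold lower number from compound 2 to compound 4 (0.21 log units; within the scatter), so replacing the nitro group with chlorines gives no readable gain here. The readable difference lies between the two halogen-bearing groups, with a 4.3-fold higher number from compound 1 to compound 4 (0.63 log units; beyond the scatter) and 2,3-dichlorophenyl ending up alongside 4-nitrophenyl rather than 3-bromophenyl; compound 4 therefore goes against any reading that a halogen on this phenyl is enough to give the lower number of compound 1. Steps involving compound 3 cannot be read, and nothing at hand bears on why these aryl groups differ.

Still open, going by these compounds, is whether the lower number of compound 1 depends on bromine itself or on the phenyl carrying a single halogen, a question that a phenyl bearing one chlorine and an unsubstituted phenyl would help to separate. Also open, on these data alone, is how a phenyl carrying an amine or a carboxylic acid at this carbon would sit relative to these three values.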